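A few compounds are considered here, and "the series" means these few. Any claim that something is new, unique, unknown or untested is made for them only; others in the source may bear on it.

The measured compounds, each with its result in a functional assay on NCI-H460 cells (Homo sapiens) for inhibition, read by sulforhodamine B assay, with a stated time of 48 h; a lower number here means a stronger inhibitor of growth, a higher number a weaker inhibitor of growth:
compound 1 `CC1=CC[C@H](C(C)(C)NC(=S)N/N=C/c2ccccc2)CC1` gives 13000 nM
compound 2 `CC1=CC[C@H](C(C)(C)NC(=S)N/N=C/c2ccc(N(C)C)cc2)CC1` gives 53400 nM

For the measured compounds named here, compound 2 stands at the higher of the two numbers, and the only measured step, a 4.1-fold higher number from compound 1 to compound 2 (0.61 log units; beyond the scatter), separates it from compound 1. Compound 3 `CC1=CC[C@H](C(C)(C)NC(=S)N/N=C/c2ccc(Cl)cc2)CC1` differs from compound 2 by chloro in place of dimethylamino on an aromatic carbon. That single step bears on this change: it shows the group at this position shifted the number, and compound 3 carries neither that group nor plain hydrogen. A modest move back toward compound 1 is expected, estimated as a 3.0-fold lower number from compound 2 to compound 3 (0.47 log units; beyond the scatter). Compound 3 is therefore estimated at 18000 nM, within 6000 nM to 55000 nM.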

Compound 3, concentration for 50% growth inhibition: 7800 nM
Compound 3: the middle estimate sits 2.3-fold (0.36 log units) above what was measured; the measured number falls inside the stated range.
By their numbers in this assay, from the lowest: compounds 3 and 1 (each within the scatter of the next); then compound 2.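

In this assay the group at this place on the aromatic ring matters in one case only: a 6.8-fold lower number from compound 2 to compound 3 (0.84 log units; beyond the scatter) shows that chloro does not share the weaker result seen with dimethylamino. Chloro and plain hydrogen cannot be told apart, since a 1.7-fold lower number from compound 1 to compound 3 (0.22 log units; within the scatter) stays within the usual scatter, so among these three compounds only dimethylamino stands apart. From the compounds shown here alone, whether a methoxy, nitro or hydroxyl group at this place would side with chloro or with dimethylamino stays open. Nothing available here accounts for the difference between chloro and dimethylamino.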